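Swapping a Thioether for an Aryl Ether on the Shared Core

This account rests on a few compounds, and the source may have more. Where it says the series, first, only, none or still open, it means among the compounds named here.

Of the compounds shown here, three built on one shared core have been tested in a functional assay on MDA-MB-435 cells (Homo sapiens) for inhibition, read by sulforhodamine B assay, with a stated time of 48 h; a higher number here means a weaker inhibitor of growth, a lower number a stronger inhibitor of growth. Compound 1 `CCOC(=O)[C@H](CCC(=O)O)NC(=O)c1ccc(Oc2nc3cc(N)cc(N)c3nc2-c2ccccc2)cc1` gives only a limit of < 100000 nM. Compound 2 `Nc1cc(N)c2nc(-c3ccccc3)c(NCc3ccc(F)cc3)nc2c1` gives 3720 nM. Compound 3 `COc1ccc(Sc2nc3cc(N)cc(N)c3nc2-c2ccccc2)cc1` likewise gives only a limit of < 100000 nM. The step that the limit leaves unreadable from compound 2 to compound 3 cannot be sized for that reason. Compound 4 `Nc1cc(N)c2nc(-c3ccccc3)c(Oc3ccc(F)cc3)nc2c1` differs from compound 3 by 4-fluorophenoxy in place of (4-methoxyphenyl)sulfanyl on an aromatic carbon. For the measured compounds named here, the only measured step at this position is the unreadable one, and compound 1, which also carries an aryl ether there, sits at the same limit (the limit of < 100000 nM in this assay, at which 2 of the 3 values shown sit). With no readable step to guide the change, compound 4 is expected to remain weak, and the expected step that the limit leaves unreadable from compound 3 to compound 4 cannot be given a direction. Compound 4 is estimated at 50000 nM, between 8000 nM and 100000 nM.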

Compound 4, concentration for total growth inhibition: 32400 nM
Estimate against measurement, compound 4: 1.5-fold (0.19 log units) above, and the stated range covers the measured number.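

This position now has its first readable step in this assay: an 8.7-fold higher number from compound 2 to compound 4 (0.94 log units; beyond the scatter), so 4-fluorophenoxy in place of (4-fluorobenzyl)amino gives a weaker inhibitor of growth. Compound 4 also shows that an aryl ether at this position can give a measured value rather than a limit. The step from the thioether of compound 3 to this ether still cannot be read: the limit of < 100000 nM in this assay, at which 2 of the 4 values shown sit.

Left open is how (4-fluorophenyl)sulfanyl would read here, which would separate the sulfur link from the methoxy group. Also open, as far as these compounds go, is whether a longer amine chain, such as (4-fluorophenethyl)amino, would change the number.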